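Anilino swap on a shared core: compound 1 to compound 3

This account rests on a few compounds, and the source may have more. Where it says the series, first, only, none or still open, it means among the compounds named here.

In a functional assay on HeLa cells (Homo sapiens) for inhibition, read by sulforhodamine B assay (a lower number here means a stronger inhibitor, a higher number a weaker inhibitor), compound 1 `Cc1ccc(NC2=CC(=O)c3nc4n(c3C2=O)[C@H]2OC[C@@H](O)[C@H]2OC4)cc1C` gives 2690 nM, the lowest of the two numbers in hand. Compound 2 `COc1ccccc1NC1=CC(=O)c2c(nc3n2[C@H]2OC[C@@H](O)[C@H]2OC3)C1=O` gives 7460 nM in this assay, a gap beyond the scatter. Compound 3 `O=C1C=C(Nc2ccc(C(F)(F)F)cc2)C(=O)c2c1nc1n2[C@H]2OC[C@@H](O)[C@H]2OC1` differs from compound 1 by 4-(trifluoromethyl)phenyl in place of 3,4-dimethylphenyl on an amine nitrogen. No measured pair isolates this kind of change, so no shown step points the way. The expected step is small, toward a higher number, and likely within or only just beyond the scatter: a 1.4-fold higher number from compound 1 to compound 3 (0.15 log units; within the scatter). For compound 3 the estimate in this assay is 3800 nM, with a range from 1300 nM to 11000 nM.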

Compound 3, half-maximal inhibitory concentration: > 8000 nM
Compound 3: a limit, no number; the forecaster's own chance of this, stated with the estimate: 5%; middle value at least 2.1-fold (0.32 log units) away from the limit.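

In this assay, compound 3 gives > 8000 nM, which is a limit of the assay and not a number. For the compounds shown here, the first readable single step at this amine nitrogen, 4-(trifluoromethyl)phenyl in place of 3,4-dimethylphenyl, is an at least 2.9-fold higher number from compound 1 to compound 3 (0.47 log units; beyond the scatter), so on the shared core this aryl group is not silent. The true size of the step remains unknown, as its reading rests on a censored value: the limit of > 8000 nM in this assay, at which 1 of the 3 values shown sits.

From the compounds shown here alone, it remains open whether the shift follows from losing 3,4-dimethylphenyl or from gaining trifluoromethyl. Also open, going by these compounds, is how a phenyl ring carrying a single methyl group, an amine or a carboxylic acid would read here.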